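This account rests on a few compounds, and the source may have more. Where it says the series, first, only, none or still open, it means among the compounds named here.

In a functional assay on A549 cells (Homo sapiens) for antiproliferative activity, read by MTT assay, with a stated time of 48 h (on this read-out higher numbers stand for weaker inhibition of growth and lower numbers for stronger inhibition of growth), compound 1 `CCOC(=O)N1N=C(c2ccccc2)CC1c1cc(OC)c(OC)c(OC)c1` gives 6680 nM. Compound 2 `COc1cc(C2CC(c3cccc(O)c3)=NN2C(=O)OCc2ccccc2)cc(OC)c1OC` reads > 10000 nM, which is a limit of the assay and not a number. Compound 3 `COC(=O)N1N=C(c2ccccc2)CC1c1ccc(OC)c(O)c1` gives 8930 nM, a value within the scatter of that of compound 1, so the two numbers cannot be told apart. Compound 4 `COC(=O)N1N=C(c2ccccc2)CC1c1ccc(OC)c(OC)c1` keeps the core of compound 3 and carries one change, methyl in place of hydrogen on an oxygen on an aromatic ring, which is hydroxy to methoxy: methyl in place of hydrogen on an oxygen on an aromatic ring. Among the measured compounds shown here, no measured pair differs by this change alone, so the data give only indirect guidance. Compound 1, which has methoxy groups and no hydroxy, stands at 6680 nM, and this suggests that no step beyond the scatter should be expected in this assay. The expected step of a 1.1-fold lower number from compound 3 to compound 4 (0.05 log units; within the scatter) is therefore small. For compound 4, the estimated value is 8000 nM, with an expected range from 3500 nM to 15000 nM.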

Compound 4, concentration for 50% growth inhibition: 7320 nM
Compound 4: middle estimate off by 1.1-fold (0.04 log units), on the high side; measured number inside the range.
By their numbers in this assay, from the lowest: compounds 1, 4 and 3 (each within the scatter of the next). At a limit, above all of these: compound 2.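

On the oxygen on the aromatic ring, hydroxy to methoxy gives a 1.2-fold lower number from compound 3 to compound 4 (0.09 log units; within the scatter) in this assay, and this is the only direct reading of the change among the compounds shown. Among the compounds shown here, the two compounds differ in this one place, so on this read-out methyl and hydrogen on that oxygen cannot be told apart, which the earlier compounds could suggest only indirectly. Nothing shown bears on why the step has this size.

The compounds shown leave open whether an amine, a carboxylic acid or a longer chain such as butyl in place of the methyl on that oxygen would move the number beyond the scatter. They also leave open whether hydroxy to methoxy reads the same on the oxygens elsewhere on this ring or with a different group on the shared core.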